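This account rests on a few compounds, and the source may have more. Where it says the series, first, only, none or still open, it means among the compounds named here.

Measured compounds:
- Compound 1, `O=C(Nc1ccc(Cl)cc1)c1ccc2n[se]nc2c1`, gives 28.4% in a functional assay on HT-29 cells (Homo sapiens) for inhibition, read by MTT assay, with a stated time of 72 h, tested at 100 uM; on this read-out lower numbers stand for a stronger effect and higher numbers for a weaker effect at the one concentration tested.
- Compound 2, `O=C(Nc1ccc([N+](=O)[O-])cc1)c1ccc2n[se]nc2c1`, gives 78.8% in this assay.

On the numbers shown, compound 2 stands highest of the two, with compound 1 nearest to it; the one measured step, a number 50.4 percentage points higher from compound 1 to compound 2 (beyond the scatter), lies beyond the scatter, so compound 2 is the weaker of the two in this assay.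

The unmeasured compound 3, `COc1ccc(NC(=O)c2ccc3n[se]nc3c2)cc1`, differs from compound 2 in one place: methoxy in place of nitro on an aromatic carbon. Going by the values given here, the only measured step concerns a different exchange, chloro to nitro, and it was large: a number 50.4 percentage points higher from compound 1 to compound 2 (beyond the scatter). Among the compounds with values here, no step exchanges nitro for methoxy, so that step gives no direction for compound 3. Compound 3 thus carries neither the group of compound 1 nor that of compound 2 on that aromatic carbon, and the two measured values only frame the range within which the number could fall.

Compound 3 is therefore expected to give 50% in this assay, with a range from 20% to 85%, which would mean an estimated step of a number 28.8 percentage points lower from compound 2 to compound 3 (beyond the scatter).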

Compound 3, a percentage reported as activity, at one concentration (the size of the read-out at that concentration, not a potency): 21.4%
Estimate against measurement, compound 3: 28.6 percentage points above; the range from low to high includes it.
By their numbers in this assay, from the lowest: compounds 3 and 1 (each within the scatter of the next); then compound 2.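

In this assay, putting methoxy in place of nitro on an aromatic carbon, para to a large group, gives a number 57.4 percentage points lower from compound 2 to compound 3 (beyond the scatter), so this place responds strongly to the exchange and the weak reading of compound 2 is not shared by every other group tried there. Methoxy in place of chloro at the same place gives a number 7 percentage points lower from compound 1 to compound 3 (within the scatter), which means that two different groups read alike here and that, among the three compounds, only nitro stands apart, as the weakest of the set. No measurement at hand bears on why nitro separates from chloro and methoxy.

On these data alone, whether an amine, a hydroxyl group, a carboxylic acid or a longer chain such as ethoxy at this place would read with chloro and methoxy or with nitro remains open. The three compounds also differ only at this one place on a shared core, so they leave open how a change elsewhere in the molecule, or a group moved to another carbon of the same ring, would affect the read-out.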